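From Methyl to Ethoxy: One Group, One Expected Step

The source may report more compounds than this note shows. Statements on the series, on what has been measured and on what is new or still open speak of the compounds shown alone.

Three compounds share one core and differ in a single group on an aromatic carbon: compound 1 `C=C(Br)C(=O)Nc1cccc(/C=C/C(=O)Nc2ccc(F)cc2)c1`, compound 2 `C=C(Br)C(=O)Nc1cccc(/C=C/C(=O)Nc2ccc(Cl)cc2)c1` and compound 3 `C=C(Br)C(=O)Nc1cccc(/C=C/C(=O)Nc2ccc(C)cc2)c1`. In a functional assay on CCRF-CEM cells (Homo sapiens) for inhibition, read by MTT assay, with a stated time of 72 h (a lower number here means a stronger inhibitor, a higher number a weaker inhibitor), compound 1 gives 16600 nM, compound 2 gives 460 nM and compound 3 gives 270 nM. Compound 3 thus cannot be told apart from compound 2, with a step of a 1.7-fold lower number from compound 2 to compound 3 (0.23 log units; within the scatter), and it lies far under compound 1, with a step of a 61-fold lower number from compound 1 to compound 3 (1.79 log units; beyond the scatter). Chloro in place of fluoro is similarly large, at a 36-fold lower number from compound 1 to compound 2 (1.56 log units; beyond the scatter).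

Compound 4 `C=C(Br)C(=O)Nc1cccc(/C=C/C(=O)Nc2ccc(OCC)cc2)c1` carries ethoxy in place of methyl on an aromatic carbon, at the same place: ethoxy in place of methyl on an aromatic carbon. Going by the values given here, no measured step involves ethoxy, so the guide is indirect. Only the fluoro compound stands apart, while chloro and methyl sit within the scatter of each other. In this assay the expected change is therefore small, a 1.5-fold higher number from compound 3 to compound 4 (0.17 log units; within the scatter), and none beyond the scatter is expected. For compound 4 the estimated value is 400 nM, with an expected range from 100 nM to 2500 nM.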

Compound 4, half-maximal inhibitory concentration: 98 nM
Compound 4: the middle estimate sits 4.1-fold (0.61 log units) above what was measured; measured number below the stated range.
By their numbers in this assay, from the lowest: compound 4; then compounds 3 and 2 (each within the scatter of the next); then compound 1.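

At this position the ceiling is not reached with chloro and methyl: ethoxy separates itself from both in this assay, with a 2.8-fold lower number from compound 3 to compound 4 (0.44 log units; beyond the scatter) and a 4.7-fold lower number from compound 2 to compound 4 (0.67 log units; beyond the scatter). The replacement of methyl by ethoxy adds an oxygen and a hydrogen-bond acceptor to the group, and the position accepts this change with a lower number, so the full span of the series widens to a 170-fold lower number from compound 1 to compound 4 (2.23 log units; beyond the scatter). Nothing measured here bears on why ethoxy gives the lowest number of the four.

The compounds shown leave open whether the step belongs to the oxygen or to the length of the chain. Methoxy, ethyl and a longer chain such as butoxy at the same place would begin to separate these two readings.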